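This account rests on a few compounds, and the source may have more. Where it says the series, first, only, none or still open, it means among the compounds named here.

Measured compounds in a functional assay on MGC-803 cells (Homo sapiens) for antiproliferative activity, read by MTT assay; on this read-out higher numbers stand for weaker inhibition and lower numbers for stronger inhibition:
- compound 1, `COc1ccccc1NC(=O)Nc1cccc(CNc2ncnc3ccccc23)c1`, gives 39300 nM
- compound 2, `COc1ccc(NC(=O)Nc2cccc(CNc3ncnc4ccccc34)c2)cc1`, gives 27300 nM
- compound 3, `COc1cc2ncnc(NCc3cccc(NC(=O)Nc4cccc(C)c4)c3)c2cc1OC`, gives 44600 nM

Compound 3 sits close to the other two: its number and that of compound 1 lie within the usual scatter of each other, and the same holds for compound 3 against compound 2, so no ranking among the three can be read from these figures. Compound 4, `COc1cc2ncnc(NCc3cccc(NC(=O)Nc4ccccc4F)c3)c2cc1OC`, has not yet been measured. It differs from compound 3 in one place: 2-fluorophenyl in place of 3-methylphenyl on an amide-type nitrogen.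

For the measured compounds named here, the only measured step that bears on a swap of the aryl group on that amide-type nitrogen is the one between compound 1 and compound 2, a 1.4-fold lower number from compound 1 to compound 2 (0.16 log units; within the scatter). That step moved a methoxy group on the same aryl ring and left this assay essentially unchanged. Going by the values given here, the change from compound 3 to compound 4 exchanges one small substituent for another on the same ring, and nothing among the measured compounds points to a shift beyond the scatter for such a swap.

Compound 4 is therefore expected to give about 40000 nM in this assay, with a likely range from 15000 nM to 100000 nM. The expected step from compound 3 to compound 4 is a 1.1-fold lower number from compound 3 to compound 4 (0.05 log units; within the scatter), meaning no change that the assay could distinguish from repeat measurement.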

Compound 4, half-maximal inhibitory concentration: 10300 nM
For compound 4 the middle estimate is 3.9-fold (0.59 log units) above the measured one; measured number below the stated range.
By their numbers in this assay, from the lowest: compound 4; then compounds 2, 1 and 3 (each within the scatter of the next).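

In this assay, the aryl group on the amide-type nitrogen proves able to move the read-out beyond the scatter (a 4.3-fold lower number from compound 3 to compound 4 (0.64 log units; beyond the scatter)), a modest step, even though 3-methylphenyl and 2-fluorophenyl have the same number of heavy atoms and the same aromatic ring of carbon. For the compounds shown here, the only earlier step at this place (a 1.4-fold lower number from compound 1 to compound 2 (0.16 log units; within the scatter)) moved a methoxy group on the core of compound 1 and stayed within the scatter, so the earlier compounds gave no sign that a change on this ring could register in the assay. Nothing available here accounts for the shift seen with compound 4.

The exchange from compound 3 to compound 4 alters both the kind of substituent and its place on the ring, so the compounds shown cannot tell whether the fluorine itself or its place goes with the lower number. They also leave open how this position would respond to an unsubstituted phenyl ring, or to a ring carrying chlorine, an amine or a carboxylic acid, and whether the same swap would give a similar step on the core of compound 1.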